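Ortho substitution on the phenylpiperazine aryl ring

A few compounds are considered here, and "the series" means these few. Any claim that something is new, unique, unknown or untested is made for them only; others in the source may bear on it.

Measured so far:
compound 1 `CN(C)C(=O)c1cccnc1NCCCN1CCN(c2ccccc2)CC1` gives 6.31 nM
compound 2 `CCCc1ccccc1N1CCN(CCCNc2ncccc2C(=O)N(C)C)CC1` gives 0.2 nM

Going by the values given here, in a functional assay for antagonist activity at Alpha-1A adrenergic receptor (Oryctolagus cuniculus) (a lower number here means tighter binding, a higher number weaker binding), compound 1 stands highest of the two numbers; its nearest neighbour is compound 2, and a 32-fold lower number from compound 1 to compound 2 (1.50 log units; beyond the scatter) is the only step seen. Compound 3 `CN(C)C(=O)c1cccnc1NCCCN1CCN(c2ccccc2C(F)(F)F)CC1` is not yet measured. It differs from compound 1 by trifluoromethyl in place of hydrogen on an aromatic carbon, on the same aromatic carbon that carries propyl in compound 2. That one step bears on it; it was large and towards a lower number. A gain of similar direction is therefore expected, though the size cannot be read off from a single example; the estimated step is a 6.3-fold lower number from compound 1 to compound 3 (0.80 log units; beyond the scatter). Compound 3 is estimated at 1 nM, with a range from 0.3 nM to 4 nM.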

Compound 3, dissociation constant: 12.6 nM
For compound 3 the middle estimate is 13-fold (1.10 log units) below the measured one; the whole stated range lies below it.
By their numbers in this assay, from the lowest: compound 2; then compounds 1 and 3 (each within the scatter of the next).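

In this assay the gain seen with propyl does not carry over to trifluoromethyl on this aromatic carbon. Trifluoromethyl in place of hydrogen gives a 2.0-fold higher number from compound 1 to compound 3 (0.30 log units; within the scatter) and trifluoromethyl in place of propyl gives a 63-fold higher number from compound 2 to compound 3 (1.80 log units; beyond the scatter) so the outcome here depends on which group enters and not merely on the carbon being substituted. Nothing at hand gives a reason for the difference between these two groups.

On these data alone, whether methoxy, ethyl or a longer chain on this carbon keeps the gain seen with propyl remains open. Also open, as far as these compounds go, is how propyl behaves on other carbons of the aromatic ring.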